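This account rests on a few compounds, and the source may have more. Where it says the series, first, only, none or still open, it means among the compounds named here.

In an ADME assay on MRC5 cells (Homo sapiens) for cytotoxicity, read by fluorescence, with a stated time of 24 h (a lower number here means a stronger inhibitor, a higher number a weaker inhibitor), compound 1 `CC1S/C(=N\N=C\c2c(-c3ccc(Br)cc3)[nH]c3ccccc23)NC1=O` gives > 50000 nM, which is a limit of the assay and not a number. Compound 2 `C=CCN1C(=O)C(CC(=O)c2ccc(F)cc2)S/C1=N\N=C1\CC2CCC1(C)C2(C)C` gives > 50000 nM, likewise a limit. Compound 3 `CCOC(=O)c1sc(N/N=C/c2c(-c3ccc(Cl)cc3)[nH]c3ccccc23)nc1C` is the only one of the three with a number, 25200 nM. Compound 1 therefore stands at the limit of > 50000 nM in this assay, at which 2 of the 3 values shown sit.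

Compound 4 `CCC1S/C(=N\N=C\c2c(-c3ccc(Br)cc3)[nH]c3ccccc23)NC1=O` has not yet been measured. It departs from compound 1 in one place, methyl in place of hydrogen on a saturated chain carbon bound to a saturated ring carbon, so that methyl becomes ethyl. For the measured compounds named here, no pair of measured compounds shows this change, so the expectation rests on how small the change is. No step beyond the usual scatter is expected in this assay, and no direction is favoured. The expected step is a number no higher from compound 1 to compound 4 (the limit leaves the size open). For compound 4 the estimated value is 50000 nM, with an expected range from 20000 nM to 100000 nM.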

Compound 4, half-maximal inhibitory concentration: 5910 nM
Beside the measured number, compound 4's estimate is 8.5-fold (0.93 log units) above it; measured number outside the range, below it.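

In this assay the change of methyl to ethyl on a saturated chain carbon bound to a saturated ring carbon gives an at least 8.4-fold lower number from compound 1 to compound 4 (0.92 log units; beyond the scatter), so it is not a silent change. The earlier compounds shown here offered no pair differing in one place, which makes this the first sign that this position bears on the read-out, and a single added carbon is enough to carry the number beyond the scatter. Compound 1 stands at a limit of the assay and not a number, so the step gives only a minimum size: the limit of > 50000 nM in this assay, at which 2 of the 4 values shown sit.

Going by these compounds, whether a longer chain such as propyl would lower the number further remains open. This single pair also cannot tell how an amine or a carboxylic acid on the same chain would act.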